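This account rests on a few compounds, and the source may have more. Where it says the series, first, only, none or still open, it means among the compounds named here.

Of the compounds shown here, three built on a shared core have been tested in a functional assay on the whole organism with Rattus norvegicus as the target; a lower number here means that less compound is needed, a higher number that more compound is needed for the effect. Compound 1 `[O-][S+](CCC(F)(F)C(F)(F)F)c1nc(-c2ccccc2)c(-c2ccccc2)[nH]1` gives > 75 mg/kg, which is a limit of the assay and not a number. Compound 2 `O=S(=O)(CCC(F)(F)C(F)(F)F)c1nc(-c2ccccc2)c(-c2ccccc2)[nH]1` gives > 75 mg/kg, which is also a limit. For the measured compounds named here, compound 3 `CS(=O)(=O)c1nc(-c2ccc(F)cc2)c(-c2ccc(C(F)(F)F)cc2)[nH]1` gives 3.7 mg/kg, the only actual number of the three, so no second measured number is available for comparison.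

Compound 4 `CS(=O)(=O)c1nc(-c2ccc(Cl)cc2)c(-c2ccc(C(F)(F)F)cc2)[nH]1` has not yet been measured. It differs from compound 3 in one place: chloro in place of fluoro on an aromatic carbon. In words, this is chloro in place of fluoro on an aromatic carbon, turning 4-fluorophenyl into 4-chlorophenyl. Going by the values given here, no measured pair shows what this swap does in this assay. With compound 3 at 3.7 mg/kg as the only anchor, no change beyond the usual scatter is expected, in either direction. The expected step of a 1.2-fold higher number from compound 3 to compound 4 (0.09 log units; within the scatter) is therefore small. For compound 4 the estimated dose is 4.5 mg/kg, with an expected range of 1.5 mg/kg to 15 mg/kg.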

Compound 4, dose for half-maximal effect: 2.2 mg/kg
The estimate for compound 4 lay 2.0-fold (0.31 log units) above the measured number; the measured number falls inside the stated range.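

For the compounds shown here, the first step that can be read on this core in this assay is a 1.7-fold lower number from compound 3 to compound 4 (0.23 log units; within the scatter), and it comes from swapping 4-fluorophenyl for 4-chlorophenyl. Chloro can therefore take the place of fluoro on this aromatic carbon with no change that stands out from repeat measurements, at least with the rest of the molecule as it is in these two compounds. Compound 1 and compound 2 add no readable step, since their values are limits of the assay and not numbers: the limit of > 75 mg/kg in this assay, at which 2 of the 4 values shown sit.

On these data alone, it remains open what happens at this same place with plain hydrogen, a methoxy group, an amine or a longer chain, any of which would test the position more sharply than one halogen for another. Also open, as far as these compounds go, is whether chloro and fluoro would stay this close on a core carrying a different group on the other phenyl ring.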